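Cytotoxicity of Compound 4 Estimated From Three Measured Analogues

A few compounds are considered here, and "the series" means these few. Any claim that something is new, unique, unknown or untested is made for them only; others in the source may bear on it.

Compound 1 `Cc1ccc(NC(=O)CSc2nncnc2-c2cccc3ccccc23)c(Br)c1`: 166000 nM
Compound 2 `COC(=O)c1ccc(NC(=O)CSc2nncnc2-c2cccc3ccccc23)c(Br)c1`: 173000 nM
Compound 3 `CCOC(=O)c1ccc(NC(=O)CSc2nncnc2-c2cccc3ccccc23)c(Br)c1`: 105000 nM

Of the compounds shown here, three sharing one core have been measured in an ADME assay on MT4 cells (Homo sapiens) for cytotoxicity, read by MTT assay; a lower number here means that less compound is tolerated, a higher number that more compound is tolerated. Compound 1 gives 166000 nM, which is the second highest of the three numbers. Its nearest neighbour is compound 2, with a 1.0-fold higher number from compound 1 to compound 2 (0.02 log units; within the scatter), and its furthest is compound 3, with a 1.6-fold lower number from compound 1 to compound 3 (0.20 log units; within the scatter). Between the two esters the step is a 1.6-fold lower number from compound 2 to compound 3 (0.22 log units; within the scatter). All three steps lie within the scatter, so the three compounds cannot be ordered on this read-out.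

Compound 4 `O=C(CSc1nncnc1-c1cccc2ccccc12)Nc1ccccc1Cl` has not been measured. It differs from compound 1 by 2-chlorophenyl in place of 2-bromo-4-methylphenyl on an amide-type nitrogen.

Within the data shown here, none of the measured steps covers this change: they all replace the methyl on the aromatic carbon with methoxycarbonyl or ethoxycarbonyl, and each stayed within the scatter. The step to compound 4 instead removes that methyl and exchanges bromine for chlorine, which the data do not address. With nothing pointing either way, compound 4 is expected to show a 1.1-fold lower number from compound 1 to compound 4 (0.04 log units; within the scatter), a step not beyond the scatter. The estimate for compound 4 in this assay is therefore 150000 nM, with a range from 70000 nM to 320000 nM.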

Compound 4, half-maximal cytotoxic concentration: 63000 nM
Compound 4: middle estimate off by 2.4-fold (0.38 log units), on the high side, and the stated range ends above it.
By their numbers in this assay, from the lowest: compounds 4, 3, 1 and 2 (each within the scatter of the next, the first and the last beyond it).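

In this assay, the change to 2-chlorophenyl in place of 2-bromo-4-methylphenyl on the amide-type nitrogen gives a 2.6-fold lower number from compound 1 to compound 4 (0.42 log units; beyond the scatter), the only step among these compounds to go beyond the scatter, whereas exchanging the methyl for either ester did not. This shows that the number can move with a change to this aromatic group, and that the two ester steps staying within the scatter did not mean that every change there would do the same; the step is modest, however, and it combines two edits, the loss of the methyl and the exchange of bromine for chlorine. Nothing available gives a measured reason for this shift.

The compounds shown leave open whether the loss of the methyl, the exchange of bromine for chlorine, or only the two together accounts for the step, since no compound here carries one edit without the other. They also leave open how this assay would respond to fluorine in place of the halogen, or to an amine or a carboxylic acid in place of the methyl.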